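The source may hold more compounds than are shown below. What is called first, only, known or untested is meant among the compounds shown, and "the series" means these compounds.

Measured compounds:
Compound 1, `Cc1ccccc1NC(=O)C(Cl)Cl`: "not determined" (no result reported) in a functional assay on A549 cells (Homo sapiens) for antiproliferative activity, read by MTT assay, with a stated time of 72 h; on this read-out lower numbers stand for stronger inhibition and higher numbers for weaker inhibition
Compound 2, `O=C(Nc1ccccc1[N+](=O)[O-])C(Cl)Cl`: 198000 nM
Compound 3, `Cc1cccc(NC(=O)C(Cl)Cl)c1`: 41100 nM

Three compounds share a dichloroacetamide attached to a substituted benzene ring. In this assay compound 1 gives "not determined" (no result reported), so no number is available for it. Compound 2 gives 198000 nM. Compound 3 gives 41100 nM, the lowest of the two reported numbers, and the gap between compound 3 and compound 2 lies beyond the usual scatter of this assay. For the measured compounds named here, with only two numbers, no broader pattern can be drawn.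

Compound 4, `O=C(Nc1cccc(Br)c1)C(Cl)Cl`, has not yet been tested. It differs from compound 3 in one place: bromo in place of methyl on an aromatic carbon. Going by the values given here, nothing among the measured compounds shows what a halogen at this position does, so the direction of the step is open. A change of one heavy atom for another on the ring is expected to shift the number only modestly, likely not beyond the scatter. The step from compound 3 to compound 4 is therefore estimated at a 1.4-fold lower number from compound 3 to compound 4 (0.14 log units; within the scatter). Compound 4 is expected to give about 30000 nM in this assay, with a plausible range from 8000 nM to 120000 nM.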

Compound 4, half-maximal inhibitory concentration: 7800 nM
Compound 4: the middle estimate sits 3.8-fold (0.59 log units) above what was measured; measured number below the stated range.
By their numbers in this assay, from the lowest: compound 4; then compound 3; then compound 2.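

In this assay, for the compounds shown here, bromo in place of methyl on this aromatic carbon gives a 5.3-fold lower number from compound 3 to compound 4 (0.72 log units; beyond the scatter), the first step that can be read at this position. The swap exchanges one heavy atom for one heavy atom, and neither group counts any hydrogen-bond donors or acceptors, yet the number moves beyond the scatter, so this position is sensitive to the identity of even a single-atom group. Nothing measured here bears on why bromo gives the lower number.

Going by these compounds alone, with only one step at this position, it remains open whether fluoro, iodo, an amine or a carboxylic acid on the same carbon would give a lower or higher number than bromo. Going by these compounds, it is equally open whether bromo on another carbon of the ring would give a similar step.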